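Acetyl to Methoxycarbonyl, Starting from a Limit

The source may hold more compounds than are shown below. What is called first, only, known or untested is meant among the compounds shown, and "the series" means these compounds.

Compound 1 (`CC(=O)N(C)CC#CCN1CCCC1`) gives > 10 mg/kg in a functional assay on the whole organism for antagonist activity, with Mus musculus as the target (on this read-out lower numbers stand for an effect already at smaller amounts and higher numbers for an effect only at larger amounts of compound), and that figure is a limit of the assay, not a number. Compound 2 (`CC(=O)N(C)CC#CCN(C)C`) gives > 10 mg/kg in this assay and this too is a limit. The record so far is thus the limit of > 10 mg/kg in this assay, at which 2 of the 2 values shown sit, and offers no measured number as a starting point. Compound 3 (`COC(=O)N(C)CC#CCN1CCCC1`) carries methoxy in place of methyl on a carbonyl carbon and otherwise keeps the core of compound 1. Within the data shown here, no measured step shows what this change does. No shift beyond the scatter is expected in this assay and the estimated step that the limit leaves unreadable from compound 1 to compound 3 leans slightly toward larger amounts. For compound 3 the estimate is 15 mg/kg with an expected range from 5 mg/kg to 50 mg/kg and a real chance that the assay again reports only a limit.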

Compound 3, dose for half-maximal effect: > 10 mg/kg
Compound 3 was reported as a limit; the forecaster's own chance of this, stated with the estimate: 60%; the middle value is on the limit's open side.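

Among these compounds, compound 1 and compound 3 both stand only as limits in this assay, so no step between them can be read: the limit of > 10 mg/kg in this assay, at which 3 of the 3 values shown sit. The compounds shown leave open whether methoxy in place of methyl on a carbonyl carbon changes the half-maximal dose at all.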